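The compounds below may be only part of what the source reports. "The series", "measured", "known", "first", "only" and "open" are said of these compounds alone.

For the measured compounds named here, in a functional assay on K562 cells (Homo sapiens) for cytotoxicity, read by MTT assay (a lower number here means a stronger inhibitor, a higher number a weaker inhibitor), compound 1 (`CC1=CCC[C@H]2[C@](C)(CC3=CC(=O)C=CC3=O)[C@@H](C)CC[C@]12C`) gives 4900 nM, the lowest of the three numbers measured so far. Compound 4 (`COC1=CC(=O)C=C(C[C@]2(C)[C@@H](C)CC[C@]3(C)C(C)=CCC[C@@H]23)C1=O`) differs from it in one place: methoxy in place of hydrogen on a double-bonded ring carbon. Two measured steps also replace a hydrogen on a double-bonded ring carbon. Compound 2 (`CC1=CCC[C@H]2[C@](C)(CC3=CC(=O)C(SC(C)C)=CC3=O)[C@@H](C)CC[C@]12C`), with isopropylsulfanyl, gives 47500 nM, which is a 9.7-fold higher number from compound 1 to compound 2 (0.99 log units; beyond the scatter). Compound 3 (`CCCCSC1=CC(=O)C(C[C@]2(C)[C@@H](C)CC[C@]3(C)C(C)=CCC[C@@H]23)=CC1=O`), with butylsulfanyl, gives 12500 nM, which is a 2.6-fold higher number from compound 1 to compound 3 (0.41 log units; beyond the scatter). Both steps raised the number, but neither brings in methoxy, so they offer only loose guidance. A moderate rise is therefore expected in this assay, and the estimated change is a 2.2-fold higher number from compound 1 to compound 4 (0.35 log units; beyond the scatter). For compound 4, the expected value is 11000 nM, with an estimated range of 3500 nM to 30000 nM.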

Compound 4, half-maximal inhibitory concentration: 2100 nM
Compound 4: middle estimate off by 5.2-fold (0.72 log units), on the high side, outside the stated range (below it).
By their numbers in this assay, from the lowest: compound 4; then compound 1; then compound 3; then compound 2.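

In this assay, methoxy on a double-bonded ring carbon, two ring bonds from the ring atom that bears a large group, gives a 2.3-fold lower number from compound 1 to compound 4 (0.37 log units; beyond the scatter). Unlike the isopropylsulfanyl and butylsulfanyl replacements, which raised the number, this one lowers it, so replacing hydrogen on such a ring carbon does not always weaken the compound. Nothing available explains this difference in direction. As far as these compounds go, whether a longer oxygen-linked chain such as ethoxy, or an amine, would also lower the number remains open.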